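A few compounds are considered here, and "the series" means these few. Any claim that something is new, unique, unknown or untested is made for them only; others in the source may bear on it.

Working notes on the aryl series. In a functional assay on A549 cells (Homo sapiens) for cytotoxicity, read by MTT assay, with a stated time of 72 h (on this read-out lower numbers stand for stronger inhibition and higher numbers for weaker inhibition), compound 1 `COc1cccc(/C(=C\c2cn(C(C)=O)c3ccc(OCc4ccccc4)cc23)C(=O)O)c1` gives 45200 nM; compound 2 `CC(=O)n1cc(/C=C(/C(=O)O)c2ccc(Cl)cc2)c2cc(OCc3ccccc3)ccc21` gives 52300 nM and compound 3 `COc1ccc(/C(=C\c2cn(C(C)=O)c3ccc(OCc4ccccc4)cc23)C(=O)O)cc1OC` gives 54800 nM. Compound 1 thus carries the smallest of the three numbers, but the steps of a 1.2-fold higher number from compound 1 to compound 2 (0.06 log units; within the scatter) and a 1.2-fold higher number from compound 1 to compound 3 (0.08 log units; within the scatter) both sit within the scatter, as does a 1.0-fold higher number from compound 2 to compound 3 (0.02 log units; within the scatter), so the three compounds are not separated on this read-out.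

Compound 4 `COc1ccc(/C(=C\c2cn(C(C)=O)c3ccc(OCc4ccccc4)cc23)C(=O)O)cc1` differs from compound 1 only at the aryl group: 4-methoxyphenyl in place of 3-methoxyphenyl on a double-bonded chain carbon bound to a carbonyl carbon and a double-bonded chain carbon. Every aryl change measured so far, including the methoxy addition from compound 1 to compound 3, left this assay unchanged within the scatter, so no step beyond the scatter is expected in this assay for compound 4, an expected step of a 1.1-fold higher number from compound 1 to compound 4 (0.04 log units; within the scatter). Compound 4 is estimated at 50000 nM, with a range of 25000 nM to 100000 nM.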

Compound 4, half-maximal inhibitory concentration: > 100000 nM
Compound 4 was reported as a limit; the forecaster's own chance of this, stated with the estimate: 10%; middle value at least 2.0-fold (0.30 log units) from the limit.
By their numbers in this assay, from the lowest: compounds 1, 2 and 3 (each within the scatter of the next). At a limit, above all of these: compound 4.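

Among these compounds, at the aryl place, on a double-bonded chain carbon bound to a carbonyl carbon and a double-bonded chain carbon, 4-methoxyphenyl in place of 3-methoxyphenyl is the first change to pass the scatter in this assay (an at least 2.2-fold higher number from compound 1 to compound 4 (0.34 log units; beyond the scatter)), although both groups have the same atoms. The value for compound 4 is a limit, not a number: the limit of > 100000 nM in this assay, at which 1 of the 4 values shown sits. Among the compounds shown here, the floors of the other two steps (an at least 1.8-fold higher number from compound 3 to compound 4 (0.26 log units; that floor lies within the scatter); an at least 1.9-fold higher number from compound 2 to compound 4 (0.28 log units; that floor lies within the scatter)) lie within the scatter, so only the step from the 3-methoxyphenyl compound is established.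

From the compounds shown here alone, the true value of compound 4 remains open. So does whether an amine or a hydroxy group in place of the methoxy of 4-methoxyphenyl would give a measurable number.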